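The source may report more compounds than this note shows. Statements on the series, on what has been measured and on what is new or still open speak of the compounds shown alone.

- Compound 1 `CN(C)C(=O)c1ncc([N+](=O)[O-])n1C`: > 100000 nM
- Compound 2 `Cn1c([N+](=O)[O-])cnc1C(=O)N1CCCC1`: > 100000 nM

In a toxicity assay on HepG2 cells (Homo sapiens) for inhibition, read by resazurin assay, with a stated time of 24 h (on this read-out lower numbers stand for higher toxicity in this test and higher numbers for lower toxicity in this test), compound 2 gives > 100000 nM, which is a limit and not a number. Compound 3 `Cn1c([N+](=O)[O-])cnc1C(=O)NC1CC1` differs from it as follows: cyclopropylamino in place of pyrrolidin-1-yl on a carbonyl carbon. It has not yet been measured. Among the compounds with values here, the only measured step that bears on this change is a step that the two limits leave unreadable from compound 1 to compound 2, and the data show (the limit of > 100000 nM in this assay, at which 2 of the 2 values shown sit). On the strength of that unreadable step, no size or direction can be derived, so no change beyond the scatter is expected. The expected step is a step that the limit leaves unreadable from compound 2 to compound 3. Compound 3 is estimated at 120000 nM, with an expected range of 50000 nM to 300000 nM.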

Compound 3, half-maximal cytotoxic concentration: > 100000 nM
Compound 3: a limit, no number; the forecaster's own chance of this, stated with the estimate: 85%; the middle value does not contradict the limit.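

In this assay compound 3 gives > 100000 nM, a limit and not a number. Within the data shown here, no step among compound 1, compound 2 and compound 3 can be read. The compounds shown leave open whether the groups on the carbonyl carbon differ at all in this assay.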